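This account rests on a few compounds, and the source may have more. Where it says the series, first, only, none or still open, it means among the compounds named here.

Compound 1 has the structure `CCCCCCCCc1ccc(OCC(=O)Cn2ncnn2)cc1`. In an ADME assay on S9 fraction from liver (Rattus norvegicus) for metabolic stability, read by LC-MS, using NADPH, with a stated time of 30 min (on this read-out lower numbers stand for a less stable compound and higher numbers for a more stable compound), compound 1 gives < 5%, which is a limit of the assay rather than a number.
Compound 2 has the structure `CCCCCCCCc1ccc(OCC(=O)Cn2nnc(-c3ccncc3)n2)cc1`. Compound 2 gives < 5%, again a limit and not a number.
Compound 3 has the structure `CCCCCCCCc1ccc(OCC(=O)Cn2nnnc2-c2ccccc2)cc1`. Compound 3 gives 36%.

Compound 3 therefore stands as the only one of the three with a real number in this assay; the other two sit at the limit of < 5% in this assay, at which 2 of the 3 values shown sit. Among the compounds with values here, the one measured step, a step that the two limits leave unreadable from compound 1 to compound 2, cannot be read in size or direction, since both ends are limits.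

Compound 4 has the structure `CCCCCCCCc1ccc(OCC(=O)Cn2nnnc2C(=O)OCC)cc1`. It differs from compound 3 in a single place: ethoxycarbonyl in place of phenyl on an aromatic carbon. Within the data shown here, no measured step changes the same part of the core in a comparable way, so there is no direct guide. What the numbers do show is that the two other groups at that ring carbon, hydrogen in compound 1 and pyridin-4-yl in compound 2, both go with a limit, while only phenyl in compound 3 gives a number. On that basis, compound 4 is expected to fall back toward the limit, with an estimated step of a number 21 percentage points lower from compound 3 to compound 4 (beyond the scatter). The estimated value for compound 4 is 15%, within a range from 4% to 35%.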

Compound 4, percent of the compound remaining: 33%
Compound 4: the middle estimate sits 18 percentage points below what was measured; the range from low to high includes it.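

In this assay, putting ethoxycarbonyl in place of phenyl on this aromatic carbon gives a number 3 percentage points lower from compound 3 to compound 4 (within the scatter), so the assay does not tell these two groups apart. Within the data shown here, this is the first readable comparison at this place, and it shows that phenyl is not the only group there that goes with a real number: ethoxycarbonyl has no ring and brings hydrogen-bond acceptors that phenyl lacks, yet the read-out stays within the usual scatter. Compounds 1 and 2 offered no such guide, as the one step between them cannot be read:  the limit of < 5% in this assay, at which 2 of the 4 values shown sit.

Two groups that differ this much give results within the scatter, but this single pair cannot say which features of a group at this ring carbon matter for stability, or why. As far as these compounds go, it remains open whether a carboxylic acid, an amine or a simple methyl on the same carbon would keep a similar amount of compound intact, and whether a longer chain in place of the ethyl part of ethoxycarbonyl would change the result.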